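From 2-hydroxypropyl to oxolan-3-yl on an aromatic nitrogen

The compounds below may be only part of what the source reports. "The series", "measured", "known", "first", "only" and "open" are said of these compounds alone.

In a functional assay on KG-1 cells (Homo sapiens) for antiproliferative activity, read by CCK-8 assay, with a stated time of 72 h (on this read-out higher numbers stand for weaker inhibition and lower numbers for stronger inhibition), three compounds on a shared core have been measured. Compound 1 `CCCn1cc(-c2n[nH]c3cc(-c4cc(C(=O)Nc5cccc(C(F)(F)F)c5)ccc4C)ccc23)cn1` gives 358 nM. Compound 2 `Cc1ccc(C(=O)Nc2cccc(C(F)(F)F)c2)cc1-c1ccc2c(-c3cnn(C4CC4)c3)n[nH]c2c1` gives 108 nM. Compound 3 `Cc1ccc(C(=O)Nc2cccc(C(F)(F)F)c2)cc1-c1ccc2c(-c3cnn(CC(C)O)c3)n[nH]c2c1` gives 339 nM.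

Adding the hydroxy group to the propyl chain shows no change beyond the scatter: a 1.1-fold lower number from compound 1 to compound 3 (0.02 log units; within the scatter). Compound 3 therefore belongs with compound 1 in the higher pair of the three numbers. Only the cyclopropyl member stands apart, as a 3.3-fold lower number from compound 1 to compound 2 (0.52 log units; beyond the scatter) and a 3.1-fold higher number from compound 2 to compound 3 (0.50 log units; beyond the scatter) show.

Compound 4 `Cc1ccc(C(=O)Nc2cccc(C(F)(F)F)c2)cc1-c1ccc2c(-c3cnn(C4CCOC4)c3)n[nH]c2c1` carries oxolan-3-yl in place of 2-hydroxypropyl on an aromatic nitrogen. The closest evidence is the single ring at this place, in compound 2 with 108 nM, set against the two open chains. Within the data shown here, that is one case only, and no measured compound has a ring with oxygen here. A lower number than for compound 3 is therefore expected, but with less confidence and a smaller size than the modest steps seen with cyclopropyl. The expected step is a 1.8-fold lower number from compound 3 to compound 4 (0.25 log units; within the scatter), which would not clearly leave the scatter. The estimate for compound 4 is 190 nM, with an expected range of 80 nM to 420 nM.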

Compound 4, half-maximal inhibitory concentration: 304 nM
Beside the measured number, compound 4's estimate is 1.6-fold (0.20 log units) below it; the measured number falls inside the stated range.
By their numbers in this assay, from the lowest: compound 2; then compounds 4, 3 and 1 (each within the scatter of the next).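

In this assay, a ring on the aromatic nitrogen is not enough on its own to give a number like that of compound 2: oxolan-3-yl, one five-membered non-aromatic ring with 1 hetero atom, gives a 1.1-fold lower number from compound 3 to compound 4 (0.05 log units; within the scatter) and a 1.2-fold lower number from compound 1 to compound 4 (0.07 log units; within the scatter), so compound 4 stands with the two open chains. Against the other ring at this place the result is a 2.8-fold higher number from compound 2 to compound 4 (0.45 log units; beyond the scatter), which leaves cyclopropyl as the only one of the four groups whose steps to all the others are beyond the scatter. Going from the 1 hydrogen-bond donor of 2-hydroxypropyl to the 0 donors of oxolan-3-yl, with 1 acceptor in both, stays within the scatter, and no measurement at hand explains any of these steps.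

Still open, as far as these compounds go, is whether the lower number of compound 2 belongs to cyclopropyl alone or extends to other all-carbon rings such as cyclobutyl or cyclopentyl. Also open, from the compounds shown here alone, is how this place responds to a ring or chain carrying an amine, such as piperidin-4-yl, or to a carboxylic acid.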